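Series notes: compound 4 as the next N-benzyl analogue

A few compounds are considered here, and "the series" means these few. Any claim that something is new, unique, unknown or untested is made for them only; others in the source may bear on it.

Of the compounds shown here, three have been measured in an assay on CHO cells for displacement of a labelled ligand from adenosine receptor A3 (Homo sapiens); on this read-out higher numbers stand for weaker inhibition and lower numbers for stronger inhibition. Compound 1 `CNC(=O)[C@H]1O[C@@H](n2cnc3c(N)nc(Cl)nc32)[C@H](O)[C@@H]1O` gives 0.398 nM, compound 3 `CNC(=O)[C@H]1O[C@@H](n2cnc3c(NC4CCCC4)nc(Cl)nc32)[C@H](O)[C@@H]1O` gives 4.27 nM, and compound 2 `CNc1nc(Cl)nc2c1ncn2[C@@H]1O[C@H](C(=O)N2CCC(Cc3ccccc3)CC2)[C@@H](O)[C@H]1O` gives 3470 nM, the highest of the three numbers; the gaps to compound 3 and to compound 1 both lie beyond the scatter. Compound 4 `O=C([C@H]1O[C@@H](n2cnc3c(NCc4cccc(I)c4)nc(Cl)nc32)[C@H](O)[C@@H]1O)N1CCC(Cc2ccccc2)CC1` differs from compound 2 by 3-iodophenyl in place of hydrogen on a saturated chain carbon bound to a nitrogen on an aromatic ring. Going by the values given here, the one measured step at the amino group, an 11-fold higher number from compound 1 to compound 3 (1.03 log units; beyond the scatter), bears only indirectly, since the new change sits on the chain carbon rather than on the nitrogen, and it raised the number. Among the compounds with values here, no measured pair shows this change itself, so a wide range is kept and no step beyond the scatter is firmly expected in this assay. For compound 4 the expected value is 1500 nM, within 100 nM to 20000 nM, which is estimated to mean a 2.3-fold lower number from compound 2 to compound 4 (0.36 log units; beyond the scatter).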

Compound 4, inhibition constant: 871 nM
For compound 4 the middle estimate is 1.7-fold (0.24 log units) above the measured one, within the range that was stated.
By their numbers in this assay, from the lowest: compound 1; then compound 3; then compound 4; then compound 2.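

At the amino group, 3-iodophenyl in place of hydrogen on a saturated chain carbon bound to a nitrogen on an aromatic ring gives a 4.0-fold lower number from compound 2 to compound 4 (0.60 log units; beyond the scatter) in this assay, a modest step. The earlier step at this amino group, an 11-fold higher number from compound 1 to compound 3 (1.03 log units; beyond the scatter), ran the other way, so compound 3 goes against compound 4 and substitution here has no single direction across these pairs. Nothing at hand accounts for either step.

Still open, as far as these compounds go, is whether 3-iodobenzyl gives a similar step on the core of compound 1. Also open, from the compounds shown here alone, is how an amine or a carboxylic acid in place of the iodine would read.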